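The source may hold more compounds than are shown below. What is called first, only, known or untested is meant among the compounds shown, and "the series" means these compounds.

Three compounds have so far been measured in a functional assay on NCI-H322M cells (Homo sapiens) for cytotoxicity, read by sulforhodamine B assay, with a stated time of 48 h; on this read-out higher numbers stand for lower toxicity in this test and lower numbers for higher toxicity in this test:

compound 1 `ClCc1ccc(Cn2cnc3c(Cl)ncnc32)cc1` gives 9330 nM
compound 2 `ClCc1cccc(Cn2cnc3c(Cl)ncnc32)c1` gives 6450 nM
compound 3 `ClCc1cccc(Cn2cnc3c(Cl)nc(Cl)nc32)c1` gives 15900 nM

Compound 1 stands second highest of these three numbers. Nearest to it is compound 2, whose number is lower but within the scatter; furthest is compound 3, whose number is higher, yet still within the scatter of compound 1. So the three measured compounds do not separate cleanly from one another.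

The unmeasured compound 4 `ClCc1ccc(Cn2cnc3c(Cl)nc(Cl)nc32)cc1` differs from compound 1 in one place: chloro in place of hydrogen on an aromatic carbon. The chloro enters on the core between two ring nitrogen atoms, meta to the chloro group already present.

Among the measured compounds shown here, one measured step bears directly on this change. The same chloro for hydrogen exchange, on the same core but with the other pattern of the benzylic chloride arm, gave a 2.5-fold higher number from compound 2 to compound 3 (0.39 log units; beyond the scatter). For the measured compounds named here, that step was modest but beyond the scatter, and it is the only guide available here; nothing in the data says whether the position of the arm alters it. On this basis compound 4 is expected to show a step of similar size, a 2.4-fold higher number from compound 1 to compound 4 (0.37 log units; beyond the scatter), towards a higher number.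

Compound 4 is therefore estimated at 22000 nM, with a range from 10000 nM to 50000 nM.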

Compound 4, concentration lethal to 50% of the cells: 50100 nM
Estimate against measurement, compound 4: 2.3-fold (0.36 log units) below, outside the stated range (above it).
By their numbers in this assay, from the lowest: compounds 2, 1 and 3 (each within the scatter of the next, the first and the last beyond it); then compound 4.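

In this assay, chloro in place of hydrogen on an aromatic carbon, between two ring nitrogen atoms, gives a 5.4-fold higher number from compound 1 to compound 4 (0.73 log units; beyond the scatter), so the move towards lower toxicity in this test now appears with both patterns of the benzylic chloride arm rather than with one. The new step looks larger than the earlier one, but the two cannot be told apart: the same change on two cores in this assay, a 2.5-fold higher number (0.39 log units; beyond the scatter) from compound 2 to compound 3 and a 5.4-fold higher number (0.73 log units; beyond the scatter) from compound 1 to compound 4, 2.2-fold (0.34 log units) apart, within the scatter of two such steps. The four compounds therefore give no sign that the position of the arm alters the effect of this chloro, and both steps, though modest, lie beyond the scatter.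

The compounds shown leave open whether the effect belongs to chloro itself, since no other group stands at this position, and an amine, a methoxy group or a methyl group there could show whether the number moves the same way. They also leave open how much the other chloro group on the core and the chloromethyl group on the arm contribute, since every compound shown carries both, and a compound with a hydroxymethyl group in place of the chloromethyl group would test the latter.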